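A few compounds are considered here, and "the series" means these few. Any claim that something is new, unique, unknown or untested is made for them only; others in the source may bear on it.

Compound 1 `CCCN(C)c1nc(C)nc2c(-c3c(C)cc(OC)cc3OC)c(C)nn12` gives 6.48 nM in an assay on cell membranes for displacement of a labelled ligand from corticotropin-releasing factor receptor 1 (Rattus norvegicus); a lower number here means a stronger inhibitor, a higher number a weaker inhibitor. Compound 2 `CCC(CC)Nc1nc(C)nc2c(-c3ccc(OC)cc3)c(C)nn12` gives 3.8 nM. Compound 3 `C=CCN(CC=C)c1nc(C)nc2c(-c3c(C)cc(OC)cc3OC)c(C)nn12` gives 1 nM.

Compound 1 has the highest number of the three; compound 2 sits within the scatter of it, while compound 3 lies beyond it. Compound 4 `COc1cc(C)c(-c2c(C)nn3c(NC4CCC4)nc(C)nc23)c(OC)c1` differs from compound 1 in one place: cyclobutylamino in place of methyl(propyl)amino on an aromatic carbon. For the measured compounds named here, the only measured step at this position is a 6.5-fold lower number from compound 1 to compound 3 (0.81 log units; beyond the scatter), which involves a different entering group. Compound 2 also carries an amine with a hydrogen-bond donor at this position, but its other differences from compound 1 leave no clean comparison. The change is therefore expected to give at most a small shift, if any beyond the scatter, perhaps toward a lower number. Compound 4 is estimated at 5 nM, within 1.5 nM to 15 nM, a step of a 1.3-fold lower number from compound 1 to compound 4 (0.11 log units; within the scatter).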

Compound 4, half-maximal inhibitory concentration: 17.4 nM
For compound 4 the middle estimate is 3.5-fold (0.54 log units) below the measured one, and the stated range ends below it.
By their numbers in this assay, from the lowest: compound 3; then compounds 2 and 1 (each within the scatter of the next); then compound 4.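

In this assay, for the compounds shown here, cyclobutylamino is the first change at this position to raise the number, with a 2.7-fold higher number from compound 1 to compound 4 (0.43 log units; beyond the scatter) and, further, a 17-fold higher number from compound 3 to compound 4 (1.24 log units; beyond the scatter). Keeping the same heavy-atom count as methyl(propyl)amino therefore does not keep the number, and the position responds to more than the size of the group. No measured evidence here accounts for this rise. The compounds shown leave open whether the ring or the hydrogen-bond donor matters more. Propylamino and methyl(cyclobutyl)amino at this position would separate the two.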